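Fluoro on the core: expected effect on ABHD6 inhibition

The source may hold more compounds than are shown below. What is called first, only, known or untested is meant among the compounds shown, and "the series" means these compounds.

Measured compounds:
compound 1 `Cc1ccc(C(=O)NC2CCCCCC2)c(=O)n1Cc1ccc(F)cc1` — > 10000 nM
compound 2 `Cc1ccc(C(=O)NC2CCCCCC2)c(OCc2ccc(F)cc2)n1` — > 10000 nM

In an assay on HEK293 cells for inhibition of Monoacylglycerol lipase ABHD6 (Homo sapiens), read by scintillation counting, with stated times of 30 min and 5 min (on this read-out higher numbers stand for weaker inhibition and lower numbers for stronger inhibition), compound 1 gives > 10000 nM, which is a limit of the assay and not a number. Compound 2, which carries the same amide and the same benzyl group on a differently linked core, also reaches only a limit in this assay, > 10000 nM. Compound 1 therefore stands at the limit of > 10000 nM in this assay, at which 2 of the 2 values shown sit, and cannot be placed against compound 2 beyond that. For the measured compounds named here, no step between measured compounds is available.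

Compound 3 `Cc1c(F)cc(C(=O)NC2CCCCCC2)c(=O)n1Cc1ccc(F)cc1` has not yet been measured. It differs from compound 1 by fluoro in place of hydrogen on an aromatic carbon, a fluoro in place of hydrogen on an aromatic carbon of the shared core. With both measured compounds sitting at the limit, nothing in the data points to a change beyond the scatter. Compound 3 is expected to remain at or near that limit, an estimated 15000 nM (range 5000 nM to 50000 nM), which means an expected step that the limit leaves unreadable from compound 1 to compound 3 that is essentially none.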

Compound 3, half-maximal inhibitory concentration: > 10000 nM
Compound 3: no number, only a limit; the forecaster's own chance of this, stated with the estimate: 75%; the middle value does not contradict the limit.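

No step from compound 1 to compound 3 can be read in this assay, since both compounds stand at the same limit: the limit of > 10000 nM in this assay, at which 3 of the 3 values shown sit.

The compounds shown leave open whether fluoro in place of hydrogen on the shared core alters inhibition at all, and what inhibition any of them reaches beyond that limit.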